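Isopropyl in place of methyl, starting from a limit

This account rests on a few compounds, and the source may have more. Where it says the series, first, only, none or still open, it means among the compounds named here.

Compound 1 `CCCCNc1nc(C)nc2c1cnn2-c1ccccc1` was tested in a functional assay on G-361 cells (Homo sapiens) for cytotoxicity, read by sulforhodamine B assay; on this read-out lower numbers stand for stronger inhibition of growth and higher numbers for weaker inhibition of growth. In this assay compound 1 gives > 100000 nM, which is a limit of the assay rather than a number. Compound 2 `Cc1nc(Nc2ccccc2)c2cnn(-c3ccccc3)c2n1` gives > 100000 nM, also a limit. Compound 3 `Cc1nc(NCc2ccccc2)c2cnn(-c3ccccc3)c2n1` gives > 100000 nM, again a limit. The steps a step that the two limits leave unreadable from compound 1 to compound 2, a step that the two limits leave unreadable from compound 1 to compound 3 and a step that the two limits leave unreadable from compound 2 to compound 3 carry no readable size because every value sits at the limit of > 100000 nM in this assay, at which 3 of the 3 values shown sit. Compound 4 `CCCCNc1nc(C(C)C)nc2c1cnn2-c1ccccc1` differs from compound 1 by isopropyl in place of methyl on an aromatic carbon. Among the measured compounds shown here, none of the measured steps touches that position, and all of them are unreadable, so no direction can be drawn from them. Compound 4 is expected to remain at the limit, with an estimated step of a number no higher from compound 1 to compound 4 (the limit leaves the size open) and an estimated value of 100000 nM, between 30000 nM and 300000 nM.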

Compound 4, concentration for total growth inhibition: > 100000 nM
Compound 4 was reported as a limit (the forecaster's own chance of this, stated with the estimate: 85%); the middle value lies on the limit itself.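

Compound 1 and compound 4 both sit at a limit of the assay rather than at a number, so no step can be read between them: the limit of > 100000 nM in this assay, at which 4 of the 4 values shown sit.

The compounds shown leave open whether isopropyl in place of methyl changes growth inhibition at all.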